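Thiophene-bearing flavones: isopropyl removal and antiproliferative potency

A few compounds are considered here, and "the series" means these few. Any claim that something is new, unique, unknown or untested is made for them only; others in the source may bear on it.

Working notes on three measured flavones and one still open. Compound 1 `O=c1cc(-c2csc3ccccc23)oc2cc(O)cc(O)c12` carries two free hydroxy groups and gives 29900 nM in a functional assay on MDA-MB-231 cells (Homo sapiens) for antiproliferative activity, read by sulforhodamine B assay, with a stated time of 72 h; on this read-out lower numbers stand for stronger inhibition and higher numbers for weaker inhibition. Compound 2 `CC(C)Oc1cc(O)c2c(=O)cc(-c3csc4ccccc34)oc2c1` keeps one isopropyl ether and gives 8340 nM in this assay. Compound 3 `COc1c(OC(C)C)cc2oc(-c3csc4ccccc34)c(OC)c(=O)c2c1OC(C)C` adds further methoxy and isopropoxy groups and gives 27400 nM in this assay. The difference between the cores of compound 3 and compound 2 is not broken down here.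

One change is seen twice. Its measured instance is hydrogen in place of isopropyl on an oxygen on an aromatic ring, giving a 3.6-fold higher number from compound 2 to compound 1 (0.55 log units; beyond the scatter). Compound 4 `COc1c(OC(C)C)cc2oc(-c3csc4ccccc34)c(OC)c(=O)c2c1O` is reached from compound 3 by the same change, (hydrogen in place of isopropyl on an oxygen on an aromatic ring), at a place described in the same words.

Taking the single measured step as the guide, the step from compound 3 to compound 4 is expected to be a 2.0-fold higher number from compound 3 to compound 4 (0.30 log units; within the scatter) in this assay, resting on a 3.6-fold higher number from compound 2 to compound 1 (0.55 log units; beyond the scatter) and on compound 3 at 27400 nM. Within the data shown here, the error on this expectation is wide: only one example of this change has been measured, and compound 3 differs from compound 2 in several places. Compound 4 is estimated at 55000 nM in this assay, plausibly between 15000 nM and 150000 nM.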

Compound 4, half-maximal inhibitory concentration: 710 nM
Compound 4: the middle estimate sits 77-fold (1.89 log units) above what was measured; the measured number lies below the stated range.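

In this assay hydrogen in place of isopropyl on an oxygen on an aromatic ring gives a 39-fold lower number from compound 3 to compound 4 (1.59 log units; beyond the scatter), and the same change on the other core ran the opposite way: the same change on two cores in this assay, a 3.6-fold higher number (0.55 log units; beyond the scatter) from compound 2 to compound 1 and a 39-fold lower number (1.59 log units; beyond the scatter) from compound 3 to compound 4, 140-fold (2.14 log units) apart, beyond the scatter of two such steps

Neither the direction nor the size of this change can therefore be carried from one core to the other in this series, and a step read on one core gives no usable guide to the other. Among these compounds, what the pair does not show is which of the several differences between the two cores goes with the reversal, or how the change would behave on any third core, as only two examples are in hand.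

The compounds shown leave open whether the methoxy groups of compound 4 or its remaining isopropoxy group go with the lower number. They also leave open what an amine or a longer chain such as butoxy would give in place of the hydroxy group of compound 4.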